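The source may hold more compounds than are shown below. What is called first, only, known or untested is meant among the compounds shown, and "the series" means these compounds.

Working notes on the series. Compound 1 `O=C(O)c1ccc2nc(O)c(-c3ccccc3)c(O)c2c1` gives > 15000 nM in an assay on isolated protein for inhibition of fatty acid synthase (Rattus norvegicus) (a higher number here means a weaker inhibitor, a lower number a stronger inhibitor), which is a limit of the measurement and not a number (the limit of > 15000 nM in this assay, at which 1 of the 3 values shown sits). Compound 2 `O=[N+]([O-])c1cccc2c(O)c(-c3ccccc3)c(O)nc12` gives 3000 nM in this assay. Going by the values given here, compound 3 `O=[N+]([O-])c1cc2c(O)c(-c3ccc(Cl)cc3Cl)c(O)nc2cc1Cl` gives 443 nM in this assay, the lowest of the numbers measured so far, and its gap to compound 2 lies beyond the scatter. Compound 4 `O=[N+]([O-])c1cc2c(O)c(-c3ccc(F)cc3F)c(O)nc2cc1Cl` differs from compound 3 by 2,4-difluorophenyl in place of 2,4-dichlorophenyl on an aromatic carbon. Among the compounds with values here, no measured pair shows this exchange, so its effect in this assay is open; a moderate rise in the number, somewhat beyond the scatter, is expected. The estimate for compound 4 in this assay is 1200 nM, with a range from 400 nM to 4000 nM. This estimate implies a 2.7-fold higher number from compound 3 to compound 4 (0.43 log units; beyond the scatter).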

Compound 4, half-maximal inhibitory concentration: 173 nM
The estimate for compound 4 lay 6.9-fold (0.84 log units) above the measured number; measured number below the stated range.
By their numbers in this assay, from the lowest: compound 4; then compound 3; then compound 2. At a limit, above all of these: compound 1.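

Going by these compounds alone, with a 2.6-fold lower number from compound 3 to compound 4 (0.41 log units; beyond the scatter) in this assay, 2,4-difluorophenyl in place of 2,4-dichlorophenyl on this aromatic carbon gives the only one-place comparison. The number at this position therefore depends on which halogen the phenyl ring carries, and the two chlorine atoms are not needed to reach this range. No value shown bears on why the step occurs. Still open, from the compounds shown here alone, is whether a single fluorine would carry the step, and how a phenyl ring bearing a methoxy group or an amine would read in this assay.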